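A few compounds are considered here, and "the series" means these few. Any claim that something is new, unique, unknown or untested is made for them only; others in the source may bear on it.

Measured compounds in this series:

- compound 1, `Nc1cc(N)c2nc(-c3ccccc3)c(Oc3ccc(Cl)c(Cl)c3)nc2c1`, in a functional assay on KM12 cells (Homo sapiens) for inhibition, read by sulforhodamine B assay, with a stated time of 48 h (a lower number here means that less compound is tolerated, a higher number that more compound is tolerated), gives < 100000 nM, which is a limit of the assay and not a number.
- compound 2, `CCOC(=O)[C@H](CCC(=O)O)NC(=O)c1ccc(Sc2nc3cc(N)cc(N)c3nc2-c2ccccc2)cc1`, gives < 100000 nM, again a limit of the assay.
- compound 3, `Nc1cc(N)c2nc(-c3ccccc3)c(Sc3ccc(F)cc3)nc2c1`, gives < 100000 nM, also a limit of the assay.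

Compound 3 therefore stands only at a limit on the numbers shown, as do the other two measured compounds, and no numeric value is known for any of them. Going by the values given here, the single step between measured compounds that differ in one place, a step that the two limits leave unreadable from compound 1 to compound 3, cannot be sized, since both of its ends are limits; the only evidence on the measured steps is the limit of < 100000 nM in this assay, at which 3 of the 3 values shown sit.

Compound 4, `Nc1cc(N)c2nc(-c3ccccc3)c(Oc3ccc(F)cc3)nc2c1`, differs from compound 3 by 4-fluorophenoxy in place of (4-fluorophenyl)sulfanyl on an aromatic carbon. Among the compounds with values here, no measured step bears directly on this change: the one measured step, a step that the two limits leave unreadable from compound 1 to compound 3, changes both the linking atom and the substituents on the ring at once, and its size is not readable. The expectation for compound 4 is thus carried by the limit at which compound 3 sits, and compound 4 is expected to give a value near 30000 nM, within 3000 nM to 100000 nM. The expected step that the limit leaves unreadable from compound 3 to compound 4 is therefore estimated as none beyond the scatter, with a high chance that the assay again reports only a limit.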

Compound 4, concentration lethal to 50% of the cells: < 100000 nM
Compound 4 gave a limit, no number; the forecaster's own chance of this, stated with the estimate: 70%; the middle value is on the limit's open side.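

The steps from compound 3 and from compound 1 to compound 4 cannot be read, as both ends of each are limits: the limit of < 100000 nM in this assay, at which 4 of the 4 values shown sit.

The compounds shown leave open whether 4-fluorophenoxy and (4-fluorophenyl)sulfanyl differ at all in this read-out, and how far any of the four compounds lies from the limit.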